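Removing the chain hydroxy from compound 3

The source may hold more compounds than are shown below. What is called first, only, known or untested is meant among the compounds shown, and "the series" means these compounds.

Of the compounds shown here, three have numbers so far in a functional assay on SK-MEL-28 cells (Homo sapiens) for inhibition, read by MTT assay, with a stated time of 48 h (on this read-out lower numbers stand for stronger inhibition and higher numbers for weaker inhibition), and the spread is modest. Compound 1 `COc1ccccc1OCCNCC(O)COc1ccc2ccccc2c1` gives 19700 nM and compound 2 `COc1ccccc1OCCNCC(O)COc1ccc(-c2ccccc2)cc1` gives 6010 nM in this series. Compound 3 `OC(CNCc1ccc(-c2ccccc2)cc1)COc1cccc(Nc2ccccc2)c1` stands at 3300 nM within the scatter of compound 2 and beyond the scatter from compound 1. Compound 4 `c1ccc(Nc2cccc(OCCCNCc3ccc(-c4ccccc4)cc3)c2)cc1` differs from compound 3 by hydrogen in place of hydroxy on a saturated chain carbon bound to two saturated chain carbons. Going by the values given here, no measured pair shows this change alone, so there is no direct guide. The expected step of a 1.1-fold lower number from compound 3 to compound 4 (0.04 log units; within the scatter) stays within the scatter in this assay with no firm direction. Compound 4 is estimated at 3000 nM (expected range 1200 nM to 8000 nM).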

Compound 4, half-maximal inhibitory concentration: 3800 nM
The estimate for compound 4 lay 1.3-fold (0.10 log units) below the measured number, within the range that was stated.
By their numbers in this assay, from the lowest: compounds 3, 4 and 2 (each within the scatter of the next); then compound 1.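

In this assay, going by these compounds alone, hydrogen in place of hydroxy on a saturated chain carbon bound to two saturated chain carbons gives a 1.2-fold higher number from compound 3 to compound 4 (0.06 log units; within the scatter) and is the only single-place step so far. On this core the chain hydroxy is thus not required to keep the number at this level, although that rests on one pair. Nothing measured here offers a reason for this result. Going by these compounds, whether an amine or a methoxy group on this carbon would move the number remains open. Also open, on these data alone, is whether losing the hydroxy would matter as little in compound 1 and compound 2.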